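A Methoxy Group on the Amide Phenyl Ring

The source may hold more compounds than are shown below. What is called first, only, known or untested is meant among the compounds shown, and "the series" means these compounds.

Measured compounds:
compound 1 `COc1ccc2c(=O)c(/C=C/C(=O)NCc3ccccc3)coc2c1`: > 200000 nM
compound 2 `COc1ccc2c(=O)c(/C=C/C(=O)Nc3ccccc3)coc2c1`: > 200000 nM

In a functional assay on L02 cells (Homo sapiens) for inhibition, read by MTT assay, with a stated time of 48 h (on this read-out lower numbers stand for stronger inhibition and higher numbers for weaker inhibition), compound 1 gives > 200000 nM, which is a limit of the assay and not a number. Compound 2 likewise gives > 200000 nM, again only a limit. For the measured compounds named here, both values sit at the limit of > 200000 nM in this assay, at which 2 of the 2 values shown sit, so the single measured step, a step that the two limits leave unreadable from compound 1 to compound 2, cannot be read in size or direction.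

Compound 3 `COc1cccc(NC(=O)/C=C/c2coc3cc(OC)ccc3c2=O)c1` is compound 2 with methoxy in place of hydrogen on an aromatic carbon. No measured step touches this position, and the one step that is shown is unreadable, so nothing here points to a change beyond the scatter. Compound 3 is therefore expected to remain at the limit as well, with an estimated value of 200000 nM, in a range from 100000 nM to 500000 nM. This corresponds to an expected step of a number no higher from compound 2 to compound 3 (the limit leaves the size open), which is no step beyond the scatter.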

Compound 3, half-maximal inhibitory concentration: > 200000 nM
Compound 3 was reported as a limit (the forecaster's own chance of this, stated with the estimate: 85%); the middle value lies on the limit itself.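

Compound 3 gives > 200000 nM, again a limit of the assay and not a number. The steps linking compound 1, compound 2 and compound 3 therefore cannot be read in size or direction: the limit of > 200000 nM in this assay, at which 3 of the 3 values shown sit.

The compounds shown leave open whether the methoxy group changes inhibition at all.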